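A few compounds are considered here, and "the series" means these few. Any claim that something is new, unique, unknown or untested is made for them only; others in the source may bear on it.

Of the compounds shown here, two have been measured so far: compound 1 `CC1=NN(C(=O)CSc2ccccc2)[C@@H](c2cc(Br)cc(Br)c2O)C1` and compound 2 `O=C(CSc1ccc([N+](=O)[O-])cc1)N1N=C(c2cc3ccccc3oc2=O)C[C@@H]1c1ccc(C(F)(F)F)cc1`. In a functional assay on MGC-803 cells (Homo sapiens) for cytotoxicity, read by MTT assay, with a stated time of 48 h (on this read-out lower numbers stand for stronger inhibition and higher numbers for weaker inhibition), compound 1 gives 12700 nM, the highest of the two numbers, and compound 2 gives 10200 nM, the nearest value, which lies within the scatter of compound 1, so no order can be drawn between them. The unmeasured compound 3 `CC1=NN(C(=O)CSc2ccc(Br)cc2)[C@@H](c2cc(Br)cc(Br)c2O)C1` differs from compound 1 by bromo in place of hydrogen on an aromatic carbon, the phenylsulfanyl group becoming a (4-bromophenyl)sulfanyl group. For the measured compounds named here, no step between measured compounds is available to gauge the effect of this change, and the two known values alone offer no pattern. For compound 3 the expected step of a 1.3-fold lower number from compound 1 to compound 3 (0.13 log units; within the scatter) is therefore judged small, leaning towards a slightly lower number but not beyond the scatter. Compound 3 is thus estimated at 9500 nM in this assay, with a range from 4000 nM to 25000 nM.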

Compound 3, half-maximal inhibitory concentration: 12800 nM
Compound 3: the middle estimate sits 1.3-fold (0.13 log units) below what was measured; measured number inside the range.
By their numbers in this assay, from the lowest: compounds 2, 1 and 3 (each within the scatter of the next).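

In this assay, for the compounds shown here, the change from phenylsulfanyl to (4-bromophenyl)sulfanyl gives a 1.0-fold higher number from compound 1 to compound 3 (0.00 log units; within the scatter), the first step that can be read at this position. On the core of compound 1, then, this aromatic carbon, para to a large group, takes a bromo with no shift that can be told from the scatter. No measurement at hand speaks to the reason for this.

One halogen cannot show whether other groups at this position, such as a methoxy group, an amine or a carboxylic acid, would also leave the number within the scatter. As far as these compounds go, it also remains open whether the same holds on other cores, such as that of compound 2, which differs from compound 1 in more than one place.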